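A few compounds are considered here, and "the series" means these few. Any claim that something is new, unique, unknown or untested is made for them only; others in the source may bear on it.

Measured compounds in a functional assay on UACC-257 cells (Homo sapiens) for inhibition, read by sulforhodamine B assay, with a stated time of 48 h; on this read-out higher numbers stand for lower toxicity in this test and lower numbers for higher toxicity in this test:

Compound 1 `COc1cc(C)cc(-c2c(-c3ccnc(-c4ccc(C(C)=O)cc4)c3)cnn2CC#N)c1` — > 100000 nM
Compound 2 `Cc1cc(O)cc(-c2nn(CC#N)cc2-c2ccnc(-c3ccc(Oc4ccccc4)cc3)c2)c1` — 31700 nM
Compound 3 `Cc1cc(O)cc(-c2nn(CC#N)cc2-c2ccnc(-c3ccc(N(C)C)cc3)c2)c1` — > 100000 nM

Compound 1 stands at the upper edge of what this assay reports: its value is a limit, not a number, and (the limit of > 100000 nM in this assay, at which 2 of the 3 values shown sit). Compound 4 `COc1cc(C)cc(-c2c(-c3ccnc(-c4ccc(N(C)C)cc4)c3)cnn2CC#N)c1` differs from compound 1 in a single place: dimethylamino in place of acetyl on an aromatic carbon. Among the compounds with values here, no measured pair shows exactly this exchange. The closest comparison is the step in which an at least 3.1-fold higher number from compound 2 to compound 3 (0.49 log units; beyond the scatter); there too a dimethylamino group enters on an aromatic carbon of the same outer ring, and the number moves upward, though the pair shares a core that differs from the core of compound 1 elsewhere, so the transfer is indirect. Because (the limit of > 100000 nM in this assay, at which 2 of the 3 values shown sit), and because an at least 3.1-fold higher number from compound 2 to compound 3 (0.49 log units; beyond the scatter) points toward higher numbers when dimethylamino enters, compound 4 is expected to remain at or above that limit rather than to fall below it. Compound 4 is therefore estimated at 100000 nM, with a range from 50000 nM to 300000 nM. The expected change is a number no higher from compound 1 to compound 4 (the limit leaves the size open), most likely reported again only as a limit.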

Compound 4, concentration lethal to 50% of the cells: > 100000 nM
Compound 4 was reported as a limit; the forecaster's own chance of this, stated with the estimate: 80%; the middle value lies on the limit itself.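

In this assay compound 1 and compound 4 are both reported only as limits, so no step can be read between them for dimethylamino in place of acetyl: the limit of > 100000 nM in this assay, at which 3 of the 4 values shown sit. The compounds shown leave open how far either compound lies past that limit, and whether this exchange moves the number at all.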